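Trimming the naphthalene substituent: what compound 4 may show

A few compounds are considered here, and "the series" means these few. Any claim that something is new, unique, unknown or untested is made for them only; others in the source may bear on it.

Compound 1: `Cc1noc(NS(=O)(=O)c2cccc3c(NC(=O)C(C)C)cccc23)c1C`, 880 nM in an assay on VSM-A10 cells for antagonist activity at Endothelin-1 receptor (Rattus norvegicus); on this read-out higher numbers stand for weaker inhibition and lower numbers for stronger inhibition
Compound 2: `Cc1noc(NS(=O)(=O)c2cccc3c(N4CCCCC4=O)cccc23)c1C`, 270 nM in this assay
Compound 3: `Cc1noc(NS(=O)(=O)c2cccc3c(NCc4ccccc4)cccc23)c1C`, 590 nM in this assay

Of the three measured compounds, compound 3 gives the second highest number. Its nearest neighbour is compound 1, and the gap between them, a 1.5-fold lower number from compound 1 to compound 3 (0.17 log units; within the scatter), lies within the scatter, so the two cannot be ordered. Compound 2 stands apart from it by a 2.2-fold higher number from compound 2 to compound 3 (0.34 log units; beyond the scatter), a modest step beyond the scatter.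

Compound 4 is `Cc1noc(NS(=O)(=O)c2cccc3ccccc23)c1C`. It differs from compound 3 by hydrogen in place of benzylamino on an aromatic carbon. Among the compounds with values here, both measured steps that end at compound 3 replace one substituent at that position with another; none removes the substituent altogether, so no measured step bears on this change directly. Those swaps, a 1.5-fold lower number from compound 1 to compound 3 (0.17 log units; within the scatter) and a 2.2-fold higher number from compound 2 to compound 3 (0.34 log units; beyond the scatter), were at most modest, which shows that the identity of the group at this position matters to a limited degree among the three. Losing the whole group is a larger change than any measured, and the author expects a higher number in this assay for compound 4, with wide uncertainty. The expected step is a 3.4-fold higher number from compound 3 to compound 4 (0.53 log units; beyond the scatter). The author estimates that compound 4 gives 2000 nM, within a range of 600 nM to 8000 nM.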

Compound 4, half-maximal inhibitory concentration: 20000 nM
The estimate for compound 4 lay 10-fold (1.00 log units) below the measured number; measured number above the stated range.
By their numbers in this assay, from the lowest: compound 2; then compounds 3 and 1 (each within the scatter of the next); then compound 4.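

In this assay, removing the substituent altogether moves the number far more than exchanging one group for another: hydrogen in place of benzylamino gives a 34-fold higher number from compound 3 to compound 4 (1.53 log units; beyond the scatter), hydrogen in place of 2-oxopiperidin-1-yl gives a 74-fold higher number from compound 2 to compound 4 (1.87 log units; beyond the scatter), and hydrogen in place of (isopropylcarbonyl)amino gives a 23-fold higher number from compound 1 to compound 4 (1.36 log units; beyond the scatter). All three steps point the same way and dwarf the largest exchange among the substituted compounds, a 3.3-fold lower number from compound 1 to compound 2 (0.51 log units; beyond the scatter), so for these compounds, the presence of a substituent on this aromatic carbon counts for much more than which of the three groups it is. Nothing presented here explains why the number rises so steeply when the group is lost.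

All three substituents attach through a nitrogen, so the compounds shown leave open whether that nitrogen alone accounts for most of the difference from compound 4 or whether the atoms beyond it are also needed. A plain primary amine at this position would address the first possibility, while an ethyl chain, attached through carbon, would show whether a substituent without that nitrogen has a similar effect.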